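Fluoro-to-hydrogen step toward compound 4

This account rests on a few compounds, and the source may have more. Where it says the series, first, only, none or still open, it means among the compounds named here.

Measured so far in a functional assay on NCI-H460 cells (Homo sapiens) for inhibition, read by CCK-8 assay, with a stated time of 48 h; a higher number here means a weaker inhibitor, a lower number a stronger inhibitor:
compound 1 `O=C(NC(=S)Nc1ccc(F)cc1)c1cn(-c2ccccc2)nc1-c1ccccc1` gives 4210 nM
compound 2 `O=C(NC(=S)Nc1ccc(Cl)cc1)c1cn(-c2ccccc2)nc1-c1ccc(Cl)cc1` gives 3260 nM
compound 3 `O=C(NC(=S)Nc1ccc(Cl)cc1)c1cn(-c2ccccc2)nc1-c1ccc(F)cc1` gives 3090 nM

Compound 3 has the lowest of the three numbers in this assay, but its nearest neighbour compound 2 and the furthest, compound 1, both sit within the scatter of it, so no order among the three can be read. Among the measured compounds shown here, the one single-point step measured, a 1.1-fold lower number from compound 2 to compound 3 (0.02 log units; within the scatter), swaps one halogen for another on the aromatic carbon and changes nothing beyond the scatter.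

Compound 4 `O=C(NC(=S)Nc1ccc(Cl)cc1)c1cn(-c2ccccc2)nc1-c1ccccc1` is not yet measured. It differs from compound 3 by hydrogen in place of fluoro on an aromatic carbon. For the measured compounds named here, no measured step removes a halogen outright at this position, so the only bearing comes from the halogen swap from compound 2 to compound 3, which was flat, and from the spread of all three values, which is also flat. The expectation for this assay is therefore a step of no more than the scatter in either direction, a 1.1-fold higher number from compound 3 to compound 4 (0.05 log units; within the scatter). Compound 4 is estimated at 3500 nM, with a range of 1800 nM to 7000 nM.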

Compound 4, half-maximal inhibitory concentration: 4020 nM
Compound 4: the middle estimate sits 1.1-fold (0.06 log units) below what was measured; the range from low to high includes it.
By their numbers in this assay, from the lowest: compounds 3, 2, 4 and 1 (each within the scatter of the next).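

In this assay, taking the halogen off this aromatic carbon altogether gives a 1.3-fold higher number from compound 3 to compound 4 (0.11 log units; within the scatter), and the same removal from the chloro analogue gives a 1.2-fold higher number from compound 2 to compound 4 (0.09 log units; within the scatter). Hydrogen, fluoro and chloro at this place, para to a large group, therefore cannot be told apart in this assay, a reading that the earlier halogen-for-halogen swap alone could not give because it never tested the bare phenyl. The new compound also allows a second reading of the halogen swap, at the other halogen-bearing aromatic carbon, with a 1.0-fold lower number from compound 1 to compound 4 (0.02 log units; within the scatter), and the swap reads the same at both places: the same change on two cores in this assay, a 1.1-fold lower number (0.02 log units; within the scatter) from compound 2 to compound 3 and a 1.0-fold higher number (0.02 log units; within the scatter) from compound 4 to compound 1, 1.1-fold (0.04 log units) apart, within the scatter of two such steps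

All four compounds remain within the scatter of one another, so the series shows no order and no group at either place that moves the number. Still open, as far as these compounds go, is whether a methoxy group, an amine or a carboxylic acid in place of the 4-fluorophenyl fluoro would shift the value beyond the scatter, and whether a carbonyl in place of the thiocarbonyl would do so on the shared core.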